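The compounds below may be only part of what the source reports. "The series", "measured", "known", "first", "only" and "open" are said of these compounds alone.

Measured so far in an assay on HEK293F cells for inhibition of cholesterol 24-hydroxylase (Homo sapiens), read by trypan blue exclusion, with stated times of 15 min and 5 h; on this read-out higher numbers stand for weaker inhibition and lower numbers for stronger inhibition:
compound 1 `O=C(NC1CC1)c1ccc(-c2cnccc2-c2ccccc2)cc1` gives 74 nM;
compound 2 `CN(C)C(=O)C1CCN(c2cnccc2-c2ccccn2)CC1` gives 68 nM;
compound 3 `Cc1cnn(-c2ccncc2N2CCC(C(=O)N(C)C)CC2)c1` gives 8.5 nM.

Compound 3 gives the lowest number of the three, and its distance to each of the others lies beyond the scatter. Compound 4 `CN(C)C(=O)C1CCN(c2cnccc2-n2cc(Br)cn2)CC1` differs from compound 3 by bromo in place of methyl on an aromatic carbon. Among the measured compounds shown here, no measured pair shows this exchange. For the measured compounds named here, the only step touching this part of the molecule is an 8.0-fold lower number from compound 2 to compound 3 (0.90 log units; beyond the scatter), which swapped the whole ring rather than a single group on it, so it gives no direction for a change at one atom of that ring. The expected step of a 1.2-fold higher number from compound 3 to compound 4 (0.07 log units; within the scatter) is therefore none beyond the scatter. Compound 4 is estimated at 10 nM, with a range from 4 nM to 25 nM.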

Compound 4, half-maximal inhibitory concentration: 9.5 nM
Estimate against measurement, compound 4: 1.1-fold (0.02 log units) above; the measured number falls inside the stated range.
By their numbers in this assay, from the lowest: compounds 3 and 4 (each within the scatter of the next); then compounds 2 and 1 (each within the scatter of the next).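

In this assay, bromo in place of methyl on this aromatic carbon of the five-membered ring gives a 1.1-fold higher number from compound 3 to compound 4 (0.05 log units; within the scatter), so the two groups cannot be told apart here. The advantage over the pyridin-2-yl ring persists with bromo, at a 7.2-fold lower number from compound 2 to compound 4 (0.85 log units; beyond the scatter), so it does not depend on the methyl group alone. Nothing available explains this result. The compounds shown carry only methyl and bromo on this carbon. On these data alone, whether an amine, a carboxylic acid or a longer chain would be tolerated there remains open.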